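This account rests on a few compounds, and the source may have more. Where it says the series, first, only, none or still open, it means among the compounds named here.

Working notes on the series in an ADME assay on WI-38 cells (Homo sapiens) for cytotoxicity, read by MTT assay, with a stated time of 72 h; on this read-out lower numbers stand for stronger inhibition and higher numbers for weaker inhibition. Compound 3 (`COc1cc(OC)cc(-c2cccc(NC(=O)CCc3ccc4c(c3)COB4O)c2)c1`) reads > 100000 nM, which is a limit and not a number. Compound 2 (`COc1cccc(-c2cccc(NC(=O)CCc3ccc4c(c3)COB4O)c2)c1`) reads > 100000 nM, which is also a limit. Among the measured compounds shown here, compound 1 (`COc1cc(OC)cc(-c2cccc(NC(=O)CCc3cccc4c3B(O)OC4)c2)c1`) gives 1700 nM, the only actual number so far, and the rest of the series sits at the limit of > 100000 nM in this assay, at which 2 of the 3 values shown sit.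

Compound 4 (`COc1cc(OC)cc(-c2cccc(NC(=O)CCc3cccc4c3COB4O)c2)c1`) has the same atoms as compound 3, joined differently: a group of 10 heavy atoms (7 carbon, 1 boron, 2 oxygen; one five-membered non-aromatic ring with 2 hetero atoms, one six-membered aromatic ring of carbon only) in place of a group of 10 heavy atoms (7 carbon, 1 boron, 2 oxygen; one five-membered non-aromatic ring with 2 hetero atoms, one six-membered aromatic ring of carbon only), on a saturated chain carbon, two bonds along the chain from a carbonyl carbon. The nearest measured precedent is an at least 58-fold higher number from compound 1 to compound 3 (1.76 log units; beyond the scatter), which also exchanges one such group for another on that chain carbon. The other step, a step that the two limits leave unreadable from compound 2 to compound 3, is methoxy in place of hydrogen on an aromatic carbon and gives no guidance.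

Compound 1 at 1700 nM shows that this kind of exchange can matter, but a single case cannot fix the size for a different arrangement. The expected change is towards a lower number, possibly with no readable value, and is estimated as an at least 5.0-fold lower number from compound 3 to compound 4 (0.69 log units; beyond the scatter). For compound 4 the estimate is 20000 nM, with an expected range of 2000 nM to 100000 nM.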

Compound 4, half-maximal inhibitory concentration: > 100000 nM
Compound 4 ended at the assay's limit (the forecaster's own chance of this, stated with the estimate: 40%); at least 5.0-fold (0.69 log units) between middle value and limit.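

Compound 4 is a second rearrangement of the same atoms on the saturated chain carbon, and it too stands far from compound 1 in this assay, with an at least 58-fold higher number from compound 1 to compound 4 (1.76 log units; beyond the scatter) as the step. The value of compound 4 is a limit, so the steps that end in it from compounds at the limit cannot be read, and no order can be given among compound 2, compound 3 and compound 4. Among the three arrangements of this group, only the one in compound 1 gives an actual number, and that one compound carries the pattern: the limit of > 100000 nM in this assay, at which 3 of the 4 values shown sit.

Still open, on these data alone, is whether the number for compound 1 survives with an amine or a carboxylic acid in place of a methoxy group. A longer chain between the amide carbonyl and the group is equally unresolved.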